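The source may hold more compounds than are shown below. What is called first, only, known or untested is meant among the compounds shown, and "the series" means these compounds.

Working notes on the series.

Three compounds sharing one core have been run in an ADME assay on microsomes from liver (Homo sapiens) for metabolic stability, tested at 2.5 uM; a lower number here means slower removal, a higher number faster removal of the compound. Compound 1 `O=S(=O)(c1ccc(F)c(Cl)c1)c1cnc2cc(F)ccc2c1-c1cccc(Cl)c1` gives 0.66 mL/min; compound 2 `O=S(=O)(c1ccc(F)c(Cl)c1)c1cnc2cc(F)ccc2c1-c1cccc(F)c1` gives 0.25 mL/min; compound 3 `O=S(=O)(c1ccc(F)c(Cl)c1)c1cnc2cc(F)ccc2c1-c1ccc(F)cc1` gives 0.69 mL/min. Compound 2 has the lowest of the three numbers: a 2.6-fold lower number from compound 1 to compound 2 (0.42 log units; beyond the scatter), and a 2.8-fold higher number from compound 2 to compound 3 (0.44 log units; beyond the scatter), while a 1.0-fold higher number from compound 1 to compound 3 (0.02 log units; within the scatter).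

Compound 4 `O=S(=O)(c1cc(Cl)cc(Cl)c1)c1cnc2cc(F)ccc2c1-c1cccc(F)c1` is not yet measured. It differs from compound 2 in one place: 3,5-dichlorophenyl in place of 3-chloro-4-fluorophenyl on a sulfonyl sulfur. For the measured compounds named here, every measured step so far concerns the aromatic carbon on the other side of the core; none touches the group on the sulfonyl sulfur, so no step in hand bears directly on this change. The measured steps were all modest or within the scatter, which suggests a change of similar size at most. For compound 4 in this assay a value near that of compound 2 is expected, estimated at 0.4 mL/min, with a likely range from 0.18 mL/min to 0.9 mL/min. The expected step is a 1.6-fold higher number from compound 2 to compound 4 (0.20 log units; within the scatter), possibly no more than the scatter.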

Compound 4, intrinsic clearance in a liver preparation (reported as CLH), per the amount of preparation that the assay uses: 0.41 mL/min
Estimate against measurement, compound 4: 1.0-fold (0.01 log units) below; measured number inside the range.
By their numbers in this assay, from the lowest: compounds 2, 4, 1 and 3 (each within the scatter of the next, the first and the last beyond it).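

In this assay, for the compounds shown here, the first measured change on the sulfonyl sulfur, 3,5-dichlorophenyl in place of 3-chloro-4-fluorophenyl, is a 1.6-fold higher number from compound 2 to compound 4 (0.21 log units; within the scatter) and so cannot be told apart from repeat measurement. For this one pair, the position on the sulfonyl sulfur accepts a second chlorine-bearing phenyl group in place of the first without a clear shift in the read-out. No available measurement explains this result.

The compounds shown leave open whether a different kind of group on the sulfonyl sulfur, such as an amine, a carboxylic acid or a longer alkyl chain, would move the number beyond the scatter. They also leave open whether this exchange would give a similar result with the 3-chlorophenyl of compound 1 or the 4-fluorophenyl of compound 3 on the aromatic carbon.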